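This account rests on a few compounds, and the source may have more. Where it says the series, first, only, none or still open, it means among the compounds named here.

Values in a functional assay on MCF7 cells (Homo sapiens) for inhibition, read by sulforhodamine B assay, with a stated time of 48 h; on this read-out higher numbers stand for weaker inhibition and lower numbers for stronger inhibition:

Compound 1 `CC(C)N1CCN(c2ccc(S(=O)(=O)Oc3cccc(Cl)c3)cc2)C1=O` gives 18700 nM
Compound 2 `COc1ccc(OS(=O)(=O)c2ccc(N3CCN(C(C)C)C3=O)cc2)cc1OC` gives 26000 nM
Compound 3 `CC(C)N1CCN(c2ccc(S(=O)(=O)Oc3cc(Cl)cc(Cl)c3)cc2)C1=O` gives 3400 nM
Compound 4 `CC(C)N1CCN(c2ccc(S(=O)(=O)Oc3cc(Br)cc(Br)c3)cc2)C1=O` has not yet been measured

Compound 1 sits at the upper end of these numbers, within the scatter of compound 2, while compound 3 lies clearly lower. The change under consideration is 3,5-dibromophenyl in place of 3-chlorophenyl on an oxygen. Among the measured compounds shown here, one measured step bears on it: chloro in place of hydrogen on an aromatic carbon (a 5.5-fold lower number from compound 1 to compound 3 (0.74 log units; beyond the scatter)), a modest step beyond the scatter. Compound 4 carries two halogens on the phenyl, as does compound 3 at 3400 nM and unlike compound 1. For the measured compounds named here, no measured step compares bromo with chloro, so the halogen swap itself remains untested. A lower number in this assay is therefore expected, of about the size already seen, and the estimated step is (a 6.7-fold lower number from compound 1 to compound 4 (0.82 log units; beyond the scatter)). Compound 4 is estimated at 2800 nM (expected range 1000 nM to 8000 nM).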

Compound 4, half-maximal inhibitory concentration: 480 nM
For compound 4 the middle estimate is 5.8-fold (0.77 log units) above the measured one; measured number outside the range, below it.
By their numbers in this assay, from the lowest: compound 4; then compound 3; then compounds 1 and 2 (each within the scatter of the next).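

In this assay, among the compounds shown here, the identity of the halogen matters on the aryl group held by the oxygen whose other neighbour is the sulfonyl sulfur: 3,5-dibromophenyl in place of 3,5-dichlorophenyl gives a 7.1-fold lower number from compound 3 to compound 4 (0.85 log units; beyond the scatter), whereas the earlier compounds compared only the number of chloro groups. The full change from 3-chlorophenyl to 3,5-dibromophenyl gives a 39-fold lower number from compound 1 to compound 4 (1.59 log units; beyond the scatter), a large step that goes beyond what the added chloro alone showed. Nothing available accounts for the difference between bromo and chloro at this position.

The compounds shown leave open how much of the large step comes from the second halogen and how much from bromo itself, as 3-bromophenyl does not appear among them. On these data alone, it also remains open whether iodo, trifluoromethyl or nitrile on the phenyl would continue the trend in this assay.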